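A few compounds are considered here, and "the series" means these few. Any claim that something is new, unique, unknown or untested is made for them only; others in the source may bear on it.

Measured compounds in a functional assay on CHO cells with adenosine receptor A1 (Homo sapiens) as the target, read by cAMP accumulation and immunoassay, with a stated time of 6 min, tested at 0.01 uM; a lower number here means a stronger effect, a higher number a weaker effect of the compound at the concentration tested:

compound 1 `Nc1scc(CN2CCN(c3ccc(Cl)cc3Cl)CC2)c1C(=O)c1ccc(Cl)cc1` gives 2%
compound 2 `COc1ccc(N2CCN(Cc3csc(N)c3C(=O)c3ccc(Cl)cc3)CC2)cc1` gives -1.2%
compound 3 `Nc1scc(CN2CCN(c3ccccc3C(F)(F)F)CC2)c1C(=O)c1ccc(Cl)cc1` gives 0%

For the measured compounds named here, all three numbers lie within the usual scatter of one another, so no compound in this set can be called more or less active than another. Compound 3 sits within the scatter of both neighbours: the step of a number 1.2 percentage points higher from compound 2 to compound 3 (within the scatter) is the nearer one, the step of a number 2 percentage points lower from compound 1 to compound 3 (within the scatter) the wider, and neither is beyond the scatter. The remaining step, a number 3.2 percentage points lower from compound 1 to compound 2 (within the scatter), is likewise within the scatter.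

Compound 4 `Nc1scc(CN2CCN(c3c(F)cccc3F)CC2)c1C(=O)c1ccc(Cl)cc1` is not yet measured. It differs from compound 3 in one place: 2,6-difluorophenyl in place of 2-(trifluoromethyl)phenyl on an amine nitrogen in a ring. Every measured step in this series exchanges one aryl group on the same ring nitrogen, and each of those exchanges left this assay unchanged within the scatter. The change to compound 4 is of the same kind at the same position, so no step beyond the scatter is expected: the estimated step is no change at the digits printed from compound 3 to compound 4 (within the scatter).

For compound 4, the expected value in this assay is therefore 0%, with a range from -10% to 10%.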

Compound 4, a percentage reported as activity, at one concentration (the size of the read-out at that concentration, not a potency): -12%
Estimate against measurement, compound 4: 12 percentage points above; the measured number lies below the stated range.
By their numbers in this assay, from the lowest: compound 4; then compounds 2, 3 and 1 (each within the scatter of the next).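

In this assay, for the compounds shown here, the aryl group on the amine nitrogen in a ring can shift the read-out after all: 2,6-difluorophenyl gives a number 12 percentage points lower from compound 3 to compound 4 (beyond the scatter) and a number 10.8 percentage points lower from compound 2 to compound 4 (beyond the scatter) and a number 14 percentage points lower from compound 1 to compound 4 (beyond the scatter) as the first steps beyond the scatter. Compound 4 therefore stands apart with the lowest number, while 2,4-dichlorophenyl, 4-methoxyphenyl and 2-(trifluoromethyl)phenyl remain within the scatter of one another. No available evidence bears on the origin of this separation.

On these data alone, whether both fluorines are needed remains open, and an unsubstituted phenyl or a phenyl with a single fluorine would test this. With one concentration, the result is the size of the read-out at that concentration and does not establish a difference in potency.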